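The compounds below may be only part of what the source reports. "The series", "measured", "known", "first", "only" and "open" are said of these compounds alone.

Working notes on a small set of pyrazole-type analogues, all read in a functional assay on 786-0 cells (Homo sapiens) for inhibition, read by sulforhodamine B assay, with a stated time of 48 h; a lower number here means a stronger inhibitor of growth, a higher number a weaker inhibitor of growth.

Compound 1 `COc1cc(C)cc(-c2c(-c3ccnc(-c4ccc(N(C)C)cc4)c3)cnn2CC#N)c1` gives only a limit in this assay, > 100000 nM, and so carries no number, in line with the limit of > 100000 nM in this assay, at which 1 of the 3 values shown sits. Compound 2 `COc1cc(C)cc(-c2nn(CC#N)cc2-c2ccnc(-c3ccc(N(C)C)cc3)c2)c1` gives 5430 nM in this assay and holds the lowest of the two numbers in the set. Compound 3 `COc1cc(C)cc(-c2nn(CC#N)cc2-c2ccc(-c3cccc(C(C)=O)c3)nc2)c1` gives 93000 nM in this assay, a gap from compound 2 that lies beyond the scatter. Going by the values given here, no pair of the measured compounds differs in a single place, so these values stand side by side as a comparison only, not as a measured step.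

Compound 4 `Cc1cc(O)cc(-c2nn(CC#N)cc2-c2ccnc(-c3ccc(N(C)C)cc3)c2)c1` is the pending member. Against compound 2 the change is hydrogen in place of methyl on an oxygen on an aromatic ring. Among the compounds with values here, no measured step in the set touches this change, so its direction in this assay cannot be read from the measured compounds; the expected step is taken as small, a 1.5-fold higher number from compound 2 to compound 4 (0.17 log units; within the scatter), expected to sit close to the scatter with a slight lean toward a higher number. On that basis compound 4 is expected to give about 8000 nM in this assay, with a range from 2500 nM to 30000 nM.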

Compound 4, concentration for total growth inhibition: 16600 nM
Compound 4: the middle estimate sits 2.1-fold (0.32 log units) below what was measured, and the stated range covers the measured number.
By their numbers in this assay, from the lowest: compound 2; then compound 4; then compound 3. At a limit, above all of these: compound 1.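

In this assay, the series now has its first measured step at a single place: going from 3-methoxy-5-methylphenyl to 3-hydroxy-5-methylphenyl gives a 3.1-fold higher number from compound 2 to compound 4 (0.49 log units; beyond the scatter). This shows that the methyl on the oxygen on the aromatic ring counts in this assay, yet its removal does not abolish the read-out, as compound 4 still gives a number, 16600 nM, rather than a limit. Nothing among the compounds shown speaks to why this change moves the number in this direction.

As far as these compounds go, with only methoxy and hydroxy at this place, it remains open whether the oxygen itself matters, and how an ethoxy group, an amine or a fluorine on the aromatic ring would read in this assay. From the compounds shown here alone, it is also open whether the same change from methoxy to hydroxy would give a step of similar size on the core of compound 3, which carries a different group on its second ring.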